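The source may hold more compounds than are shown below. What is called first, only, known or untested is meant among the compounds shown, and "the series" means these compounds.

Measured so far in an assay on the whole organism (plasma, strain Sprague-Dawley) for inhibition of Dipeptidyl peptidase 4 (Rattus norvegicus), with a stated time of 10 h, at a dose of 1 mg/kg by the oral route; on this read-out lower numbers stand for less inhibition and higher numbers for more inhibition at the one dose given (going by the name of the read-out):

compound 1, `C[C@@H]1N[C@H](C(=O)N2CCC[C@H]2C#N)C[C@@H]1C(=O)N1CCC1`: 88%
compound 2, `C[C@@H]1N[C@H](C(=O)N2CCC[C@H]2C#N)C[C@@H]1C(=O)N1CCSCC1`: 85%
compound 3, `N#C[C@@H]1CCCN1C(=O)[C@@H]1C[C@H](C(=O)N2CCCCC2)CN1`: 50%

Compound 3 stands lowest of the three numbers in this assay; its gap to compound 2 and to compound 1 is beyond the scatter in both cases, whereas compounds 1 and 2 give numbers within the scatter of each other. For the measured compounds named here, the only single-place step measured is a number 3 percentage points lower from compound 1 to compound 2 (within the scatter), one ring in place of another ring on the carbonyl carbon, and it changed nothing beyond the scatter.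

Compound 4, `CN(C)C(=O)[C@@H]1CN[C@H](C(=O)N2CCC[C@H]2C#N)C1`, differs from compound 3 as follows: dimethylamino in place of piperidin-1-yl on a carbonyl carbon. Going by the values given here, no measured step covers a ring giving way to an acyclic group at that carbonyl carbon, so the step from compound 1 to compound 2 bears on it only loosely. What the numbers show is that the group on this carbonyl carbon can move the read-out in this assay by a large amount, since compound 3 sits far below compounds 1 and 2 with a different ring there. In this assay compound 4 is therefore expected to land somewhere between the low number of compound 3 and the high numbers of compounds 1 and 2, with a wide range.

The expected step is a number 15 percentage points higher from compound 3 to compound 4 (beyond the scatter), upward but uncertain. Compound 4 is estimated at 65%, within 40% to 85%.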

Compound 4, a percentage reported as inhibition, in the whole organism at one dose (the size of the read-out at that dose, not a potency): 52%
For compound 4 the middle estimate is 13 percentage points above the measured one; low and high end bracket the measured number.
By their numbers in this assay, from the lowest: compounds 3 and 4 (each within the scatter of the next); then compounds 2 and 1 (each within the scatter of the next).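

In this assay the position gives a number 2 percentage points higher from compound 3 to compound 4 (within the scatter), with dimethylamino in place of piperidin-1-yl on a carbonyl carbon, so on the core of compound 3 a ring at this place is not required to hold the read-out. Together with a number 3 percentage points lower from compound 1 to compound 2 (within the scatter), this gives two single-place changes on a carbonyl carbon that stay within the scatter: one ring for another on the core of compound 1, and an acyclic group for a ring on the core of compound 3. No measurement at hand accounts for the absence of a change in this step.

Still open, on these data alone, is whether morpholin-4-yl or a longer chain such as diethylamino on this carbonyl carbon would leave the read-out unchanged. Also open, as far as these compounds go, is whether a free carboxylic acid in place of the amide would do so.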